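Triazole nitrogen substituent change in a trifluoromethyl chromene series

The compounds below may be only part of what the source reports. "The series", "measured", "known", "first", "only" and "open" are said of these compounds alone.

Compound 1 `CCOC(=O)C1=Cc2ccccc2OC1(OCc1cc(-c2ccc(OC)cc2)no1)C(F)(F)F`, compound 2 `CCOC(=O)C1=Cc2ccccc2OC1(OCc1cn(CC(=O)Nc2cccc(F)c2)nn1)C(F)(F)F` and compound 3 `CCOC(=O)C1=Cc2ccccc2OC1(OCc1cn(CC(=O)Nc2ccccc2Br)nn1)C(F)(F)F` were tested in a functional assay on MCF7 cells (Homo sapiens) for inhibition, read by MTT assay, with a stated time of 24 h; a lower number here means a stronger inhibitor, a higher number a weaker inhibitor. Compound 1 reached only the limit of the assay, > 150000 nM. Compound 2 likewise gave only a limit, > 150000 nM. Compound 3 also gave only a limit, > 150000 nM.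

Compound 3 therefore stands nowhere definite on the numbers shown: all three values sit at the same limit, as the limit of > 150000 nM in this assay, at which 3 of the 3 values shown sit, records. Going by the values given here, the one measured step that touches compound 3, a step that the two limits leave unreadable from compound 2 to compound 3, cannot be read for size, since both ends are limits.

Compound 4 `CCOC(=O)C1=Cc2ccccc2OC1(OCc1cn(-c2ccccc2)nn1)C(F)(F)F` differs from compound 3 as follows: phenyl in place of ((2-bromophenyl)carbamoyl)methyl on an aromatic nitrogen. Among the compounds with values here, no measured step speaks to this change; the only neighbouring step is unreadable.

Compound 4 is expected to stay at or near the limit in this assay, estimated at 200000 nM with a range from 50000 nM to 1000000 nM. The expected step that the limit leaves unreadable from compound 3 to compound 4 is thus estimated to be none beyond the scatter.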

Compound 4, half-maximal inhibitory concentration: > 150000 nM
Compound 4 gave a limit, no number; the forecaster's own chance of this, stated with the estimate: 80%; the middle value does not contradict the limit.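

In this assay compound 4 gave only a limit, > 150000 nM. No new step can be read, since the comparisons of compound 4 with compound 2 and compound 3 have limits at both ends. The compounds shown leave open which change, if any, would give a measurable value, as all of them share one result: the limit of > 150000 nM in this assay, at which 4 of the 4 values shown sit.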